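Changing the Amide Substituent of Compound 1: Expected Cytotoxicity

The source may report more compounds than this note shows. Statements on the series, on what has been measured and on what is new or still open speak of the compounds shown alone.

Measured compounds:
compound 1 `O=C(CSc1nncnc1-c1cccc2ccccc12)Nc1ccccc1[N+](=O)[O-]` — 142000 nM
compound 2 `O=C(CSc1nncnc1-c1ccccc1Cl)Nc1ccccc1[N+](=O)[O-]` — 63000 nM

In an ADME assay on MT4 cells (Homo sapiens) for cytotoxicity, read by MTT assay (on this read-out lower numbers stand for higher toxicity in this test and higher numbers for lower toxicity in this test), compound 1 gives 142000 nM, the highest of the two numbers. Compound 2 gives 63000 nM, which is a 2.3-fold lower number from compound 1 to compound 2 (0.35 log units; beyond the scatter). Compound 3 `O=C(CSc1nncnc1-c1cccc2ccccc12)N1CCc2ccccc2C1` differs from compound 1 in one place: 1,2,3,4-tetrahydroisoquinolin-2-yl in place of (2-nitrophenyl)amino on a carbonyl carbon. Going by the values given here, the only measured step concerns the aromatic group on the core, not the carbonyl carbon, so no measured step bears on this change. With nothing to guide the direction, compound 3 is expected to stay close to compound 1, meaning a 1.3-fold lower number from compound 1 to compound 3 (0.11 log units; within the scatter) within the scatter. Compound 3 is therefore estimated at 110000 nM, between 35000 nM and 300000 nM.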

Compound 3, half-maximal cytotoxic concentration: 13000 nM
The estimate for compound 3 lay 8.5-fold (0.93 log units) above the measured number; the whole stated range lies above it.
By their numbers in this assay, from the lowest: compound 3; then compound 2; then compound 1.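

The carbonyl carbon proves to be a position that matters in this assay: the change gives an 11-fold lower number from compound 1 to compound 3 (1.04 log units; beyond the scatter). The entering group has the same count of 10 heavy atoms as the leaving one, but it carries 0 hydrogen-bond donors and 0 acceptors, against 1 donor and 2 acceptors, so heavy-atom count alone does not track this step. No available evidence accounts for the shift.

Going by these compounds, it remains open which feature of the exchange goes with the lower number, and whether phenylamino or piperidin-1-yl on this carbonyl carbon would follow it.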